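The source may report more compounds than this note shows. Statements on the series, on what has been measured and on what is new or still open speak of the compounds shown alone.

Compound 1 `NNC(=O)CCc1ccncc1-c1ccc2ccccc2c1`: > 10000 nM
Compound 2 `CNC(=O)/C=C/c1ccncc1-c1ccc2cc[nH]c2c1`: 9230 nM
Compound 3 `Cn1ncc2cc(-c3cnccc3/C=C/C(=O)O)ccc21`: > 10000 nM

All three compounds were tested in a functional assay on MCF7 cells (Homo sapiens) for inhibition, read by sulforhodamine B assay, with a stated time of 72 h; on this read-out higher numbers stand for weaker inhibition of growth and lower numbers for stronger inhibition of growth. Compound 1 gives > 10000 nM, which is a limit of the assay and not a number. Compound 3 also gives a limit, > 10000 nM. On these data alone, compound 1 therefore stands at the limit of > 10000 nM in this assay, at which 2 of the 3 values shown sit, and its true position is unknown. Among the compounds with values here, compound 2 is the only one with a measured number, 9230 nM.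

Compound 4 `CNC(=O)CCc1ccncc1-c1ccc2ccccc2c1` departs from compound 1 at a single place, with methyl in place of amino on an amide-type nitrogen. Within the data shown here, no measured pair shows the effect of this change. Compound 2 also carries a methylcarbamoyl group and gives 9230 nM, so the expectation is of no marked gain in growth inhibition. The expected step of a number no higher from compound 1 to compound 4 (the limit leaves the size open) is small, with no direction beyond the scatter. The assay may well report only a limit again. For compound 4 the estimate is 10000 nM, with an expected range from 4000 nM to 20000 nM.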

Compound 4, concentration for 50% growth inhibition: > 10000 nM
Compound 4: a limit, no number (the forecaster's own chance of this, stated with the estimate: 60%); the middle value lies on the limit itself.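

Within the data shown here, compound 1 and compound 4 both stand at a limit of the assay and not at a number, so no step between them can be read: the limit of > 10000 nM in this assay, at which 3 of the 4 values shown sit. The compounds shown leave open whether methyl in place of amino on an amide-type nitrogen changes growth inhibition at all, and by how much.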